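The source may report more compounds than this note shows. Statements on the series, on what has been measured and on what is new or still open speak of the compounds shown alone.

Notes on the series. In a functional assay on HepG2 cells (Homo sapiens) for cytotoxicity, read by MTT assay, with a stated time of 48 h (a higher number here means a weaker inhibitor, a lower number a stronger inhibitor), compound 1 `COc1cc(-c2nnc3n2NC(c2ccco2)C(C(=O)c2ccc(F)c(F)c2)S3)cc(OC)c1OC` gives 52400 nM as a number. Compound 2 `COc1cc(-c2nnc3n2NC(c2ccco2)C(C(=O)c2ccco2)S3)cc(OC)c1OC` reaches only the limit of this assay, which is > 100000 nM here. Compound 3 `COc1cc(-c2nnc3n2NC(c2ccco2)C(C(=O)c2cccc(Br)c2)S3)cc(OC)c1OC` likewise sits at the limit, reported as > 100000 nM in this assay. Two of the three values thus stand at the limit of > 100000 nM in this assay, at which 2 of the 3 values shown sit, and compound 2 is one of them, so its place on the numbers is known only as a limit. Compound 4 `COc1cc(-c2nnc3n2NC(c2ccco2)C(C(=O)c2ccc(Cl)cc2)S3)cc(OC)c1OC` is not yet measured; it differs from compound 2 by 4-chlorophenyl in place of furan-2-yl on a carbonyl carbon on that carbonyl carbon. The measured steps on the same carbonyl carbon are an at least 1.9-fold higher number from compound 1 to compound 2 (0.28 log units; that floor lies within the scatter) and a step that the two limits leave unreadable from compound 2 to compound 3; in addition an at least 1.9-fold higher number from compound 1 to compound 3 (0.28 log units; that floor lies within the scatter) shows that a bromophenyl group there also ends at the limit, while compound 1 with its difluorophenyl is the only aryl case that sits beneath it. The step to compound 4 is therefore expected to be an at least 1.1-fold lower number from compound 2 to compound 4 (0.07 log units; that floor lies within the scatter), at most a modest fall in the number. Compound 4 is estimated at 85000 nM, within 40000 nM to 200000 nM, with a fair chance that this assay again reports only a limit.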

Compound 4, half-maximal inhibitory concentration: 78600 nM
Estimate against measurement, compound 4: 1.1-fold (0.03 log units) above; the range from low to high includes it.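

In this assay, compound 4 gives a number rather than a limit, so a numeric value on this carbonyl carbon is no longer confined to the 3,4-difluorophenyl group of compound 1. The comparison between these two aryl groups reads a 1.5-fold higher number from compound 1 to compound 4 (0.18 log units; within the scatter), so 4-chlorophenyl and 3,4-difluorophenyl cannot be told apart here. Against the two compounds held at a limit, the steps are an at least 1.2-fold lower number from compound 2 to compound 4 (0.10 log units; that floor lies within the scatter) and an at least 1.2-fold lower number from compound 3 to compound 4 (0.10 log units; that floor lies within the scatter), and neither floor separates 4-chlorophenyl from furan-2-yl or 3-bromophenyl.

The true size of these steps stays unknown, and the step between compound 2 and compound 3 cannot be read, with some of the values still resting on this limit: the limit of > 100000 nM in this assay, at which 2 of the 4 values shown sit.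

Going by these compounds, whether an amine or a carboxylic acid in place of the aryl group on this carbonyl carbon would move the number beyond the scatter remains open.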